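Chloro for fluoro on two cores: cytotoxicity notes

A few compounds are considered here, and "the series" means these few. Any claim that something is new, unique, unknown or untested is made for them only; others in the source may bear on it.

Measured compounds:
compound 1, `C#C[C@]1(CO)O[C@@H](n2cc(F)c(=O)[nH]c2=O)C[C@@H]1O`, 3400 nM
compound 2, `C#C[C@]1(CO)O[C@@H](n2cc(Cl)c(=O)[nH]c2=O)C[C@@H]1O`, 81700 nM
compound 3, `C#C[C@]1(CO)O[C@@H](n2cc(F)c(N)nc2=O)C[C@@H]1O`, > 100000 nM

In a functional assay on MT4 cells (Homo sapiens), read by MTT assay (on this read-out higher numbers stand for lower toxicity in this test and lower numbers for higher toxicity in this test), compound 1 gives 3400 nM. Compound 2 differs by chloro in place of fluoro on an aromatic carbon and this gives a 24-fold higher number from compound 1 to compound 2 (1.38 log units; beyond the scatter). Among the compounds with values here, for compound 3 the value > 100000 nM is a limit of this assay, not a number; it is the one value that sits at the limit of > 100000 nM in this assay, at which 1 of the 3 values shown sits. How the core of compound 3 differs from that of compound 1 is not broken down here.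

Compound 4, `C#C[C@]1(CO)O[C@@H](n2cc(Cl)c(N)nc2=O)C[C@@H]1O`, is not yet measured. It differs from compound 3 by chloro in place of fluoro on an aromatic carbon, the same kind of change as from compound 1 to compound 2, except that here the carbon is ortho to an amino group (1 heavy atom) rather than to a group of 1 heavy atom. Resting on a 24-fold higher number from compound 1 to compound 2 (1.38 log units; beyond the scatter), the step is expected to be a step that the limit leaves unreadable from compound 3 to compound 4, though compound 3 already sits at a limit, so a number may not appear. Compound 4 is expected at 250000 nM, within 100000 nM to 1000000 nM.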

Compound 4, half-maximal cytotoxic concentration: > 100000 nM
Compound 4: a limit, no number; the forecaster's own chance of this, stated with the estimate: 85%; the middle value does not contradict the limit.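

Compound 3 and compound 4 both stand at a limit in this assay, not at a number, so no step between them can be read: the limit of > 100000 nM in this assay, at which 2 of the 4 values shown sit.

As far as these compounds go, whether chloro in place of fluoro shifts the number on the core of compound 3 as it does on the core of compound 1 stays open.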